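Aryl-to-Thiophene Swap on the Amine Nitrogen of Compound 1

This account rests on a few compounds, and the source may have more. Where it says the series, first, only, none or still open, it means among the compounds named here.

Compound 1 `NCc1cc(F)ccc1CN(Cc1nc2ccccc2[nH]1)C1CCCc2cccnc21`: 219 nM
Compound 2 `NCc1cc(C(N)=O)ccc1CN(Cc1nc2ccccc2[nH]1)C1CCCc2cccnc21`: 15 nM
Compound 3 `CO/N=C/c1ccc(CN(Cc2nc3ccccc3[nH]2)C2CCCc3cccnc32)c(CN)c1`: 5 nM

In a functional assay on CEM-CCRF cells for antagonist activity at C-X-C chemokine receptor type 4 (Homo sapiens), read by calcium flux (a higher number here means a weaker inhibitor, a lower number a stronger inhibitor), compound 1 gives the highest of the three numbers. Compound 2 lies a 15-fold lower number from compound 1 to compound 2 (1.16 log units; beyond the scatter) and compound 3 lies a 44-fold lower number from compound 1 to compound 3 (1.64 log units; beyond the scatter), with a 3.0-fold lower number from compound 2 to compound 3 (0.48 log units; beyond the scatter) between them. Compound 4 `NCc1cscc1N(Cc1nc2ccccc2[nH]1)C1CCCc2cccnc21` differs from compound 1 by a group of 7 heavy atoms (5 carbon, 1 nitrogen, 1 sulfur; one five-membered aromatic ring with 1 hetero atom) in place of a group of 10 heavy atoms (8 carbon, 1 nitrogen, 1 fluorine; one six-membered aromatic ring of carbon only), on an amine nitrogen. Among the measured compounds shown here, none of the measured steps touches this position; all three alter a substituent on the six-membered ring that is itself removed here, so they show only that this arm is sensitive to change. For the measured compounds named here, with no step bearing directly on the swap, a move in either direction is possible, and a weakening is expected for compound 4 at a 3.2-fold higher number from compound 1 to compound 4 (0.50 log units; beyond the scatter). Compound 4 is therefore estimated at 700 nM, within 100 nM to 5000 nM.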

Compound 4, half-maximal inhibitory concentration: 13 nM
Compound 4: middle estimate off by 54-fold (1.73 log units), on the high side; the whole stated range lies above it.
By their numbers in this assay, from the lowest: compound 3; then compounds 4 and 2 (each within the scatter of the next); then compound 1.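

Replacing the whole arm on the amine nitrogen, and not just a substituent on it, gives a 17-fold lower number from compound 1 to compound 4 (1.23 log units; beyond the scatter) in this assay. The six-membered aromatic ring of carbon only is therefore not needed for activity at this position, and a five-membered aromatic ring with 1 hetero atom serves in its place. Nothing available explains this gain.

The fluorine leaves together with the ring, so the compounds shown cannot separate the two changes. They also leave open how a phenyl ring without fluorine or a furan ring would behave here.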